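This account rests on a few compounds, and the source may have more. Where it says the series, first, only, none or still open, it means among the compounds named here.

In a functional assay on HeLa cells (Homo sapiens) for inhibition, read by sulforhodamine B assay (on this read-out higher numbers stand for weaker inhibition and lower numbers for stronger inhibition), three compounds sharing one core have been tested. Compound 1 `O=C1C=C(NCc2ccccc2)C(=O)c2c1nc1n2[C@H]2OC[C@@H](O)[C@H]2OC1` carries a benzyl group on the amine nitrogen; in this assay compound 1 gives > 8000 nM, which is a limit of the assay rather than a number. Compound 2 `COc1ccc(NC2=CC(=O)c3c(nc4n3[C@H]3OC[C@@H](O)[C@H]3OC4)C2=O)cc1` carries a 4-methoxyphenyl group on that nitrogen; in this assay compound 2 gives > 8000 nM, again a limit. Going by the values given here, compound 3 `CCOc1ccc(NC2=CC(=O)c3nc4n(c3C2=O)[C@H]2OC[C@@H](O)[C@H]2OC4)cc1` carries a 4-ethoxyphenyl group, and in this assay compound 3 gives 3110 nM, the only real number among the three, the other two sitting at the limit of > 8000 nM in this assay, at which 2 of the 3 values shown sit. Among the compounds with values here, the step of an at least 2.5-fold lower number from compound 1 to compound 3 (0.41 log units; beyond the scatter) is the only measured step that touches this position. Compound 4 `COc1cccc(NC2=CC(=O)c3nc4n(c3C2=O)[C@H]2OC[C@@H](O)[C@H]2OC4)c1` has yet to be measured. It differs from compound 3 in one place: 3-methoxyphenyl in place of 4-ethoxyphenyl on an amine nitrogen. Within the data shown here, no measured step bears directly on this swap. Because compound 2 with its 4-methoxyphenyl sits at the limit of > 8000 nM in this assay, at which 2 of the 3 values shown sit, while compound 3 gives a number, a weakening step a 1.9-fold higher number from compound 3 to compound 4 (0.29 log units; within the scatter) is expected here. Compound 4 is therefore estimated at 6000 nM, with a range from 2500 nM to 14000 nM.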

Compound 4, half-maximal inhibitory concentration: 4280 nM
For compound 4 the middle estimate is 1.4-fold (0.15 log units) above the measured one; measured number inside the range.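

In this assay, the change gives a 1.4-fold higher number from compound 3 to compound 4 (0.14 log units; within the scatter), so a 3-methoxyphenyl group and a 4-ethoxyphenyl group on the amine nitrogen cannot be told apart, and a real number at this position is not tied to the 4-ethoxyphenyl group alone. Set against the benzyl group, the change gives an at least 1.8-fold lower number from compound 1 to compound 4 (0.27 log units; that floor lies within the scatter), so this step alone does not separate the two compounds. Compound 2, with its 4-methoxyphenyl group, remains at a limit of the assay, so not every methoxyphenyl group on this nitrogen yields a number: the limit of > 8000 nM in this assay, at which 2 of the 4 values shown sit.

On these data alone, how an unsubstituted phenyl group or a longer chain such as 4-butoxyphenyl would read on this nitrogen remains open. Also open, as far as these compounds go, is whether any group here can bring the number well below those of compound 3 and compound 4.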